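The compounds below may be only part of what the source reports. "The series", "measured", "known", "first", "only" and "open" are said of these compounds alone.

Among the measured compounds shown here, in a functional assay on CCRF-CEM cells (Homo sapiens) for antiproliferative activity (a higher number here means a weaker inhibitor of growth, a lower number a stronger inhibitor of growth), compound 1 `COCCCCCCCCCCCCCCC/C=C1\CC(CO)(COC(=O)C(C)(C)C)OC1=O` gives 4.26 ug/mL and compound 2 `CC(=O)OCCCCCCCCCCCCCCC/C=C1\CC(CO)(COC(=O)C(C)(C)C)OC1=O` gives 7.55 ug/mL, so compound 2 stands within the scatter of the only other measured value. Compound 3 `CC(C)(C)C(=O)OCCCCCCCCCCCCCCC/C=C1\CC(CO)(COC(=O)C(C)(C)C)OC1=O` differs from compound 2 by tert-butyl in place of methyl on a carbonyl carbon. For the measured compounds named here, the one measured step that bears on this is a 1.8-fold higher number from compound 1 to compound 2 (0.25 log units; within the scatter), acetyl in place of methyl on an oxygen on a saturated carbon. Going by the values given here, no measured step lies beyond the scatter, and no such step is expected in this assay. The expected step is a 1.1-fold lower number from compound 2 to compound 3 (0.03 log units; within the scatter). For compound 3 the estimated value is 7 ug/mL, with an expected range of 3 ug/mL to 16 ug/mL.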

Compound 3, concentration for 50% growth inhibition: > 10 ug/mL
Compound 3 ended at the assay's limit (the forecaster's own chance of this, stated with the estimate: 3%); middle value at least 1.4-fold (0.15 log units) away from the limit.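

In this assay compound 3 gives > 10 ug/mL as a limit of the assay and not a number: the limit of > 10 ug/mL in this assay, at which 1 of the 3 values shown sits.

Tert-butyl in place of methyl on a carbonyl carbon gives an at least 1.3-fold higher number from compound 2 to compound 3 (0.12 log units; that floor lies within the scatter) and so stays unresolved from the acetyl ester. Among the compounds shown here, the larger change at this end of the chain gives an at least 2.3-fold higher number from compound 1 to compound 3 (0.37 log units; beyond the scatter) and is the first step to reach beyond the scatter.

Going by these compounds, how far compound 3 actually lies from its limit remains open. Also open, on these data alone, is how a free hydroxyl, an amine or a carboxylic acid at this end of the chain would read.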